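A few compounds are considered here, and "the series" means these few. Any claim that something is new, unique, unknown or untested is made for them only; others in the source may bear on it.

Values in an in vitro ADME assay on microsomes from liver (Homo sapiens) for metabolic stability, tested at 1 uM; on this read-out lower numbers stand for a shorter-lived compound and higher numbers for a longer-lived compound
- compound 1 `CS(=O)(=O)Nc1ccc2c(c1)S(=O)(=O)N=C(C1=C(O)[C@@H]3[C@H]4CC[C@H](C4)[C@@H]3N(Cc3ccccc3)C1=O)N2` gives > 1 h (a limit)
- compound 2 `CS(=O)(=O)Nc1ccc2c(c1)S(=O)(=O)N=C(C1=C(O)[C@@H]3[C@H]4CC[C@H](C4)[C@@H]3N(Cc3ccc(F)c(Cl)c3)C1=O)N2` gives > 1 h (a limit)
- compound 3 `CC(C)CCN1C(=O)C(C2=NS(=O)(=O)c3cc(NS(C)(=O)=O)ccc3N2)=C(O)[C@@H]2[C@H]3CC[C@H](C3)[C@@H]21` gives 0.617 h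

Among the compounds with values here, compound 3 carries the only true number of the three, and the other two values are limits. The next compound to be read is compound 4 `CS(=O)(=O)Nc1ccc2c(c1)S(=O)(=O)N=C(C1=C(O)[C@@H]3[C@H]4CC[C@H](C4)[C@@H]3N(CC3CCCCC3)C1=O)N2`, and the change leading to it is cyclohexyl in place of isobutyl on a saturated chain carbon bound to an amide-type nitrogen in a ring. In words, this is cyclohexyl in place of isobutyl on a saturated chain carbon bound to an amide-type nitrogen in a ring.

Within the data shown here, two measured steps touch this place: an at least 1.6-fold lower number from compound 1 to compound 3 (0.20 log units; that floor lies within the scatter) and an at least 1.6-fold lower number from compound 2 to compound 3 (0.20 log units; that floor lies within the scatter). Both are floors only, and both floors lie within the scatter. The third step, a step that the two limits leave unreadable from compound 1 to compound 2, gives no size. Neither readable step replaces an open chain with a non-aromatic ring, so none measures this change directly. The expectation therefore starts from compound 3 at 0.617 h. Compound 4 has a ring at this place, as compound 1 and compound 2 do, so a reading at the limit remains possible.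

The expected outcome in this assay is no shift beyond the scatter, a 1.0-fold lower number from compound 3 to compound 4 (0.01 log units; within the scatter). The estimate for compound 4 is 0.6 h, with an expected range of 0.27 h to 1.3 h.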

Compound 4, half-life: 0.733 h
For compound 4 the middle estimate is 1.2-fold (0.09 log units) below the measured one, and the stated range covers the measured number.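

In this assay, within the data shown here, cyclohexyl in place of isobutyl gives a 1.2-fold higher number from compound 3 to compound 4 (0.07 log units; within the scatter), the first direct reading of a non-aromatic ring against an open chain on a saturated chain carbon bound to an amide-type nitrogen in a ring, and it separates the two groups by no more than the scatter. Cyclohexyl in place of phenyl gives an at least 1.3-fold lower number from compound 1 to compound 4 (0.13 log units; that floor lies within the scatter) and cyclohexyl in place of 3-chloro-4-fluorophenyl gives an at least 1.3-fold lower number from compound 2 to compound 4 (0.13 log units; that floor lies within the scatter), so compound 4 shows that a ring at this place can still give a true number rather than a limit, but neither floor establishes a gap beyond the scatter. Both floors start from a limit of the assay, which leaves the true size of these steps unknown: the limit of > 1 h in this assay, at which 2 of the 4 values shown sit.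

Going by these compounds, the step between the two limits, from compound 1 to compound 2, cannot be read, so any difference between phenyl and 3-chloro-4-fluorophenyl remains open. Also open, on these data alone, is whether an amine, a carboxylic acid or a longer chain at this place would move the half-life beyond the scatter from the values of the saturated groups.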